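Cyano for trifluoromethyl on a benzylpiperazine in a cytotoxicity series

This account rests on a few compounds, and the source may have more. Where it says the series, first, only, none or still open, it means among the compounds named here.

Measured compounds:
compound 1, `CCN(CC)c1ccc2cc(C(=O)c3ccc(N4CCN(C(=O)CN5CCN(C(=O)CCl)CC5)CC4)cc3)oc2c1`, 20900 nM
compound 2, `CCN(CC)c1ccc2cc(C(=O)c3ccc(N4CCN(C(=O)CN5CCN(Cc6ccc(C(F)(F)F)cc6)CC5)CC4)cc3)oc2c1`, 6540 nM

Two compounds have numbers in an ADME assay on L02 cells (Homo sapiens) for cytotoxicity, read by MTT assay, with a stated time of 48 h; a lower number here means a stronger inhibitor, a higher number a weaker inhibitor. Compound 1 gives 20900 nM, and compound 2 gives 6540 nM. Within the data shown here, the single step between them, a 3.2-fold lower number from compound 1 to compound 2 (0.50 log units; beyond the scatter), replaces a (chloromethyl)carbonyl group on an amine nitrogen in a ring with a 4-(trifluoromethyl)benzyl group. On these two numbers compound 2 has the lowest number, with compound 1 as its nearest neighbour.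

Compound 3, `CCN(CC)c1ccc2cc(C(=O)c3ccc(N4CCN(C(=O)CN5CCN(Cc6ccc(C#N)cc6)CC5)CC4)cc3)oc2c1`, has not yet been measured in this assay. It differs from compound 2 by cyano in place of trifluoromethyl on an aromatic carbon. Among the measured compounds shown here, no measured step of this kind exists in the set; the only step known, from compound 1 to compound 2, exchanges a whole substituent on the piperazine and so says little about a change on the aromatic ring of the benzyl group. The cyano and trifluoromethyl groups sit at the same position on the same ring, so a step no larger than the scatter is expected, a 1.2-fold higher number from compound 2 to compound 3 (0.09 log units; within the scatter). Compound 3 is estimated at 8000 nM, with a range from 3000 nM to 22000 nM.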

Compound 3, half-maximal inhibitory concentration: 29600 nM
Compound 3: middle estimate off by 3.7-fold (0.57 log units), on the low side; the measured number lies above the stated range.
By their numbers in this assay, from the lowest: compound 2; then compounds 1 and 3 (each within the scatter of the next).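

Cyano in place of trifluoromethyl on this aromatic carbon is not a neutral exchange in this assay (a 4.5-fold higher number from compound 2 to compound 3 (0.66 log units; beyond the scatter)). The earlier drop on replacing (chloromethyl)carbonyl with 4-(trifluoromethyl)benzyl (a 3.2-fold lower number from compound 1 to compound 2 (0.50 log units; beyond the scatter)) therefore does not carry over to every benzyl group of this kind: 4-cyanobenzyl in the same place gives a step that stays within the scatter (a 1.4-fold higher number from compound 1 to compound 3 (0.15 log units; within the scatter)). Among these compounds, then, the lower number goes with the 4-(trifluoromethyl)benzyl group of compound 2, and no measurement is available that accounts for the difference between the two groups.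

The compounds shown carry only trifluoromethyl and cyano on this ring, so it stays open whether a chlorine atom, a methoxy group or an amine at the same place would give a number like that of compound 2 or like that of compound 3. They also leave open whether the same exchange would give a step of similar size if the benzyl group were lengthened to a phenethyl chain.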